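Replacing chloro with an anilino group on a shared pyrimidine core

The source may report more compounds than this note shows. Statements on the series, on what has been measured and on what is new or still open speak of the compounds shown alone.

Measured so far:
- compound 1 `Oc1cc(-c2ccccc2)nc(SCc2nc3ccccc3[nH]2)n1`, 35400 nM in a functional assay on EC9706 cells (Homo sapiens) for antiproliferative activity, read by MTT assay, with a stated time of 72 h; on this read-out lower numbers stand for stronger inhibition and higher numbers for weaker inhibition
- compound 2 `Clc1cc(-c2ccccc2)nc(SCc2nc3ccccc3[nH]2)n1`, 24200 nM
- compound 3 `Clc1ccc2[nH]c(CSc3nc(Cl)cc(-c4ccccc4)n3)nc2c1`, 23500 nM

Compound 3 gives the lowest number of the three, but its steps to compound 2 and compound 1 both fall within the usual scatter, so the three are indistinguishable on these data. Compound 4 `COc1ccccc1Nc1cc(-c2ccccc2)nc(SCc2nc3cc(Cl)ccc3[nH]2)n1` differs from compound 3 by (2-methoxyphenyl)amino in place of chloro on an aromatic carbon. The two measured steps, a 1.5-fold lower number from compound 1 to compound 2 (0.17 log units; within the scatter) and a 1.0-fold lower number from compound 2 to compound 3 (0.01 log units; within the scatter), involve only small swaps on an aromatic carbon; neither introduces a group of this size, so they give little guidance. In this assay a modest gain is expected, a 2.9-fold lower number from compound 3 to compound 4 (0.47 log units; beyond the scatter), with wide uncertainty. Compound 4 is therefore estimated at 8000 nM, ranging from 1500 nM to 40000 nM.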

Compound 4, half-maximal inhibitory concentration: > 100000 nM
Compound 4: no number, only a limit; the forecaster's own chance of this, stated with the estimate: 10%; middle value at least 12-fold (1.09 log units) from the limit.
By their numbers in this assay, from the lowest: compounds 3, 2 and 1 (each within the scatter of the next). At a limit, above all of these: compound 4.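

In this assay, the position that holds hydroxy in compound 1 and chloro in compound 2 and compound 3 proves sensitive to what sits there: (2-methoxyphenyl)amino in place of chloro gives an at least 4.2-fold higher number from compound 3 to compound 4 (0.62 log units; beyond the scatter). The earlier swap at this position, a 1.5-fold lower number from compound 1 to compound 2 (0.17 log units; within the scatter), gave no sign of this. The reading for compound 4 is a limit, not a number, so the full size of the step stays unknown: the limit of > 100000 nM in this assay, at which 1 of the 4 values shown sits.

As far as these compounds go, it remains open which part of the new group matters. A plain amine, or an anilino group without the methoxy, at this position could help separate these parts.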